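Swapping Methoxy for Fluoro on a Non-Toxic Core

The compounds below may be only part of what the source reports. "The series", "measured", "known", "first", "only" and "open" are said of these compounds alone.

Compound 1, `COc1cccc(-c2cnc(NC(=O)c3ccc(F)cc3)n2C)c1`, was tested in a toxicity assay on THP-1 cells (Homo sapiens) for inhibition; on this read-out higher numbers stand for lower toxicity in this test and lower numbers for higher toxicity in this test. Compound 1 gives > 100000 nM, which is a limit of the assay rather than a number. Two close relatives share its core. Compound 2, `COc1ccc(-c2cnc(NC(=O)c3ccno3)n2C)cc1`, gives > 100000 nM in this assay, again a limit. Compound 3, `COc1cccc(-c2cnc(NC(=O)c3ncc[nH]3)n2C)c1`, gives > 100000 nM, also a limit. Among the compounds with values here, the one computable step, a step that the two limits leave unreadable from compound 1 to compound 3, therefore has no readable size, and the whole picture is summed up by the limit of > 100000 nM in this assay, at which 3 of the 3 values shown sit.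

Compound 4, `Cn1c(-c2cccc(F)c2)cnc1NC(=O)c1ccc(F)cc1`, has not yet been measured. It differs from compound 1 in one place: fluoro in place of methoxy on an aromatic carbon. Within the data shown here, no measured step touches this change, since the single measured step alters the group on the carbonyl carbon rather than the six-membered aromatic ring of carbon only. With every measured compound sitting at the limit, nothing points to a move into measurable toxicity. Compound 4 is therefore expected to give 100000 nM in this assay, with a range from 50000 nM to 300000 nM, most likely reported again as a limit. The estimated change is a number no higher from compound 1 to compound 4 (the limit leaves the size open), that is, no step beyond the scatter.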

Compound 4, half-maximal cytotoxic concentration: 58000 nM
Estimate against measurement, compound 4: 1.7-fold (0.24 log units) above; the measured number falls inside the stated range.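

Within the data shown here, compound 4 is the first compound here to give a measured number rather than a limit in this assay, which shows that this position, on an aromatic carbon of the ring carrying the methoxy group in compound 1, can matter for the read-out. Going by these compounds, the change of 3-methoxyphenyl to 3-fluorophenyl gives an at least 1.7-fold lower number from compound 1 to compound 4 (0.23 log units; that floor lies within the scatter), so any rise in toxicity that can be vouched for is still no larger than the usual scatter, and the true size stays open. The wider picture has barely moved, with most of the compounds still held at one ceiling: the limit of > 100000 nM in this assay, at which 3 of the 4 values shown sit.

The compounds shown do not tell whether an amine, a carboxylic acid or a longer chain at this position would lower the number further. They also leave open whether fluoro in place of methoxy would have any readable effect with the 1H-imidazol-2-yl group of compound 3.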